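Replacing the Benzyl Arm with Cyclohexyl on the Core

The source may report more compounds than this note shows. Statements on the series, on what has been measured and on what is new or still open speak of the compounds shown alone.

Compound 1 `O=C(O)c1ccccc1-c1ccc(CCc2ncc(Cc3cccc(Cl)c3)[nH]2)cc1` gives 825 nM in an in vitro functional assay on cells for agonist activity at Bombesin receptor subtype-3 (Homo sapiens), read by luminescence and calcium flux; on this read-out lower numbers stand for an effect already at smaller amounts and higher numbers for an effect only at larger amounts of compound. Compound 2 `N#Cc1ccc(Cc2cnc(CCc3ccc(-c4ccccc4C(=O)O)cc3)[nH]2)cc1` gives 5890 nM in this assay and so carries the higher of the two numbers, the change being a 7.1-fold higher number from compound 1 to compound 2 (0.85 log units; beyond the scatter). Compound 3 `O=C(O)c1ccccc1-c1ccc(CCc2ncc(C3CCCCC3)[nH]2)cc1` differs from compound 2 by cyclohexyl in place of 4-cyanobenzyl on an aromatic carbon. Within the data shown here, no measured step covers this exchange; the only guide is that swapping the arm already moved the number modestly, as a 7.1-fold higher number from compound 1 to compound 2 (0.85 log units; beyond the scatter) shows. The step is therefore expected to be a 2.4-fold lower number from compound 2 to compound 3 (0.37 log units; beyond the scatter), in either direction possible. Compound 3 is estimated at 2500 nM, within 500 nM to 12000 nM.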

Compound 3, half-maximal effective concentration: 375 nM
The estimate for compound 3 lay 6.7-fold (0.82 log units) above the measured number, outside the stated range (below it).
By their numbers in this assay, from the lowest: compound 3; then compound 1; then compound 2.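

In this assay, an aromatic ring on this carbon of the five-membered ring proves unnecessary: cyclohexyl, with fewer heavy atoms and no nitrile, gives a 16-fold lower number from compound 2 to compound 3 (1.20 log units; beyond the scatter) and a 2.2-fold lower number from compound 1 to compound 3 (0.34 log units; beyond the scatter). Both benzyl arms therefore give higher numbers than the non-aromatic ring, whereas the earlier step compared only two benzyl arms. Nothing available explains this difference. As far as these compounds go, it remains open whether a smaller cyclopentyl ring, a longer cyclohexylmethyl chain or a piperidine ring carrying an amine nitrogen would lower the number further.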